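This account rests on a few compounds, and the source may have more. Where it says the series, first, only, none or still open, it means among the compounds named here.

Measured compounds:
Compound 1 `O=C1/C(=C/c2cccc(Br)c2)CCc2cc(O)ccc21`: 1140 nM
Compound 2 `O=C1/C(=C/c2cccc(O)c2)CCc2cc(O)ccc21`: 3510 nM
Compound 3 `O=C1/C(=C/c2cccc(Br)c2)CCc2ccc(O)cc21`: 480 nM

All three values come from a functional assay on RAW264.7 cells (Mus musculus) for inhibition; on this read-out higher numbers stand for weaker inhibition and lower numbers for stronger inhibition. Compound 2 differs from compound 1 by one change, (hydroxy in place of bromo on an aromatic carbon), and that change gave a 3.1-fold higher number from compound 1 to compound 2 (0.49 log units; beyond the scatter). Compound 3 carries the same atoms as compound 1 joined differently; how the two cores differ is not broken down here. Of the three, compound 3 gives the lowest number in this assay, with compound 1 nearest and compound 2 furthest away.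

Compound 4 `O=C1/C(=C/c2cccc(O)c2)CCc2ccc(O)cc21` has not yet been measured. It stands to compound 3 as compound 2 stands to compound 1: the difference is hydroxy in place of bromo on an aromatic carbon, and since the place of the change is described in the same terms for both pairs, it is the same change. Going by the values given here, the one measured instance of it is the step from compound 1 to compound 2, which moved the number beyond the usual scatter. On that single precedent, the estimate for compound 4 in this assay is a step of about a 3.1-fold higher number from compound 3 to compound 4 (0.49 log units; beyond the scatter), because the same change gave a 3.1-fold higher number from compound 1 to compound 2 (0.49 log units; beyond the scatter). Compound 4 is therefore expected to give roughly 1500 nM, most likely between 700 nM and 3200 nM.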

Compound 4, half-maximal inhibitory concentration: 810 nM
For compound 4 the middle estimate is 1.9-fold (0.27 log units) above the measured one, and the stated range covers the measured number.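

In this assay, hydroxy in place of bromo on an aromatic carbon gives a 1.7-fold higher number from compound 3 to compound 4 (0.23 log units; within the scatter) and so stays within the usual scatter on this second core. Set beside the earlier instance, the two steps cannot be told apart: the same change on two cores in this assay, a 3.1-fold higher number (0.49 log units; beyond the scatter) from compound 1 to compound 2 and a 1.7-fold higher number (0.23 log units; within the scatter) from compound 3 to compound 4, 1.8-fold (0.26 log units) apart, within the scatter of two such steps. Going by these compounds alone, this shows that the change carried from one core to the other without a detectable difference in its size, but it does not establish that the size is the same on both cores or that it would hold on any further core, as the evidence is only two pairs and only the first step lies beyond the scatter.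

The compounds shown carry only bromo or hydroxy at the place of change, which leaves open how an amine, a carboxylic acid or a methoxy group there would read in this assay. Also open is whether the change would hold on a core other than the two shown here.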